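The source may hold more compounds than are shown below. What is called first, only, known or untested is meant among the compounds shown, and "the series" means these compounds.

Within the data shown here, compound 2 `Fc1ccc(-c2cc3ccccc3[nH]2)cc1` stands highest of the two numbers so far in an assay on isolated protein for inhibition of Aromatase (Homo sapiens), read by fluorescence, using NADPH, with a stated time of 30 min, tested at 50 uM (a lower number here means less inhibition, a higher number more inhibition at the concentration tested (going by the name of the read-out)), where compound 2 gives 21.8%; the nearest is compound 1 `Cc1ccc(-c2cc3ccccc3[nH]2)cc1`, which in this assay gives 9.33%. Among the measured compounds shown here, the single measured step, a number 12.5 percentage points higher from compound 1 to compound 2 (beyond the scatter), alters the same aromatic carbon that is varied again here. Compound 3 `FC(F)(F)Oc1ccc(-c2cc3ccccc3[nH]2)cc1` differs from compound 2 by trifluoromethoxy in place of fluoro on an aromatic carbon. For the measured compounds named here, only that one step bears on the change, and its entering group differs, so it guides loosely. From compound 2 a modest rise of a number 8.2 percentage points higher from compound 2 to compound 3 (within the scatter) is expected. Compound 3 is estimated at 30%, between 15% and 50%.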

Compound 3, a percentage reported as inhibition, at one concentration (the size of the read-out at that concentration, not a potency): 1.86%
Compound 3: middle estimate off by 28.1 percentage points, on the high side; measured number below the stated range.
By their numbers in this assay, from the lowest: compounds 3 and 1 (each within the scatter of the next); then compound 2.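

At this aromatic carbon, trifluoromethoxy does not carry on the gain seen with fluoro: this assay shows a number 19.9 percentage points lower from compound 2 to compound 3 (beyond the scatter) on this change. Against methyl, the same group gives a number 7.5 percentage points lower from compound 1 to compound 3 (within the scatter) and so cannot be told apart from it, which leaves fluoro as the only one of the three groups that stands clear of the others here. Nothing measured here accounts for this result.

The compounds shown leave open how an amine or a carboxylic acid at this carbon would read. They also leave open whether methoxy, which keeps the oxygen without the three fluorines, would read nearer to fluoro or to trifluoromethoxy.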